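A Hydroxyl Added to the Methoxyphenyl Group

The source may hold more compounds than are shown below. What is called first, only, known or untested is meant among the compounds shown, and "the series" means these compounds.

Measured so far in a functional assay on HL-60 cells (Homo sapiens) for antiproliferative activity, with a stated time of 72 h; on this read-out higher numbers stand for weaker inhibition and lower numbers for stronger inhibition:
- compound 1 `Cc1cccc(CNc2ncnc3c2ncn3[C@@H]2O[C@H](CO)[C@@H](O)[C@H]2O)c1`: 6400 nM
- compound 2 `COc1ccccc1CNc1ncnc2c1ncn2[C@@H]1O[C@H](CO)[C@@H](O)[C@H]1O`: 2300 nM
- compound 3 `OC[C@H]1O[C@@H](n2cnc3c(NCc4cc(F)cc(F)c4)ncnc32)C(O)C1O`: 9100 nM

Compound 2 has the lowest number of the three, and its distances to compound 1 and compound 3 both lie beyond the scatter. Compound 4 `COc1cccc(CNc2ncnc3c2ncn3[C@@H]2O[C@H](CO)[C@@H](O)[C@H]2O)c1O` is not yet measured. It differs from compound 2 in one place: 2-hydroxy-3-methoxyphenyl in place of 2-methoxyphenyl on a saturated chain carbon bound to a nitrogen on an aromatic ring.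

Among the measured compounds shown here, the only measured step that bears on this is the exchange of one aryl group for another, a 2.8-fold lower number from compound 1 to compound 2 (0.44 log units; beyond the scatter). For the measured compounds named here, that step was modest, and no measured pair shows what an added hydroxyl does here, so only a small step is expected for compound 4, if any beyond the scatter, a 1.3-fold higher number from compound 2 to compound 4 (0.12 log units; within the scatter). Compound 4 is therefore estimated at 3000 nM, within 1200 nM to 8000 nM.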

Compound 4, half-maximal inhibitory concentration: 150 nM
For compound 4 the middle estimate is 20-fold (1.30 log units) above the measured one; measured number outside the range, below it.
By their numbers in this assay, from the lowest: compound 4; then compound 2; then compounds 1 and 3 (each within the scatter of the next).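

Exchanging the 2-methoxyphenyl group for 2-hydroxy-3-methoxyphenyl on the saturated chain carbon gives a large step (a 15-fold lower number from compound 2 to compound 4 (1.19 log units; beyond the scatter)), so this place responds far more strongly than the modest earlier exchange suggested. Measured against the 3-methylphenyl group, the same new group gives a larger step still (a 43-fold lower number from compound 1 to compound 4 (1.63 log units; beyond the scatter)). No supporting evidence is available to explain this result.

The compounds shown leave open whether the hydroxyl or the placement of the methoxy group carries the step, and how a 2-hydroxyphenyl group alone would compare. Also open, from the compounds shown here alone, is what an amine or a carboxylic acid on this ring would do.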